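This account rests on a few compounds, and the source may have more. Where it says the series, first, only, none or still open, it means among the compounds named here.

For the measured compounds named here, compound 2 `CSc1ccc2c(Cc3cccc(C(=O)O)n3)c(-c3ccccc3)nn2c1` gives 87 nM in a functional assay on cells for antagonist activity at prostaglandin E2 receptor EP1 subtype (Rattus norvegicus), read by fluorescence and calcium flux, with a stated time of 60 s (a higher number here means a weaker inhibitor, a lower number a stronger inhibitor), the lower of the two numbers measured so far. Going by the values given here, its nearest neighbour, compound 1 `O=C(O)c1cccc(Cc2c(-c3ccccc3)nn3cc(F)ccc23)n1`, gives 380 nM in this assay, and the single measured step, a 4.4-fold lower number from compound 1 to compound 2 (0.64 log units; beyond the scatter), came from putting methylsulfanyl in place of fluoro on an aromatic carbon. Compound 3 `CS(=O)(=O)c1ccc2c(Cc3cccc(C(=O)O)n3)c(-c3ccccc3)nn2c1` differs from compound 2 only by methylsulfonyl in place of methylsulfanyl on an aromatic carbon. Among the compounds with values here, no measured step swaps one sulfur group for another, so the only guide is that a change at this same position has already moved the number by a modest but real amount. A step of similar size in this assay seems plausible, but its direction is open, with a slight lean toward a weaker inhibitor. Compound 3 is therefore expected to give about 180 nM in this assay, within 60 nM to 550 nM, a step of a 2.1-fold higher number from compound 2 to compound 3 (0.32 log units; beyond the scatter).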

Compound 3, half-maximal inhibitory concentration: 5400 nM
Compound 3: middle estimate off by 30-fold (1.48 log units), on the low side; measured number above the stated range.
By their numbers in this assay, from the lowest: compound 2; then compound 1; then compound 3.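

The number at this position depends heavily on the group attached: a 62-fold higher number from compound 2 to compound 3 (1.79 log units; beyond the scatter) in this assay is much larger than the earlier 4.4-fold lower number from compound 1 to compound 2 (0.64 log units; beyond the scatter) and comes from changing only methylsulfanyl to methylsulfonyl. Two added oxygens on the same sulfur are enough to turn the best of the three groups into the worst, so a sulfur group at this aromatic carbon does not by itself give a strong inhibitor. Fluoro also does better than methylsulfonyl here, with a 14-fold higher number from compound 1 to compound 3 (1.15 log units; beyond the scatter) in this comparison, so the order runs methylsulfanyl, fluoro, methylsulfonyl from the lowest number to the highest.

Still open, going by these compounds, is how a methylsulfinyl group, with one oxygen on the sulfur, a methoxy group or a longer ethylsulfanyl chain would read at this position. On these data alone, whether the same order would hold with other changes to the shared core is also open. What lies behind the size of this step cannot be said from the information at hand.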